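Swapping the ortho group: cytotoxicity of compound 4

A few compounds are considered here, and "the series" means these few. Any claim that something is new, unique, unknown or untested is made for them only; others in the source may bear on it.

Measured so far:
- compound 1, `Cc1ccccc1/C=C/C(=O)NNC(=O)c1ccc2c(c1)OCCO2`: 268000 nM
- compound 2, `O=C(/C=C/c1ccccc1Cl)NNC(=O)c1ccc2c(c1)OCCO2`: 285000 nM
- compound 3, `COc1ccccc1/C=C/C(=O)NNC(=O)c1ccc2c(c1)OCCO2`: 312000 nM

All three compounds share one core and differ only in the group on an aromatic carbon, ortho to a large group. In an ADME assay on cells (Macrophage) for cytotoxicity, read by MTT assay, with a stated time of 24 h (on this read-out higher numbers stand for lower toxicity in this test and lower numbers for higher toxicity in this test), compound 1 gives the lowest of the three numbers, but every gap is small: the step of a 1.1-fold higher number from compound 1 to compound 2 (0.03 log units; within the scatter) and the step of a 1.2-fold higher number from compound 1 to compound 3 (0.07 log units; within the scatter) both stay within the scatter, as does the step of a 1.1-fold higher number from compound 2 to compound 3 (0.04 log units; within the scatter). On these numbers, then, the three compounds cannot be told apart.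

Compound 4, `O=C(/C=C/c1ccccc1F)NNC(=O)c1ccc2c(c1)OCCO2`, has not yet been measured. Its change from compound 1 is fluoro in place of methyl on an aromatic carbon at the same place where the other two changes sit. Within the data shown here, the steps that bear on it are those from compound 1 to compound 2 and from compound 1 to compound 3, both within the scatter, so no step beyond the scatter is expected in this assay here either.

Compound 4 is therefore expected to give about 285000 nM in this assay, with a likely range from 190000 nM to 430000 nM, meaning an expected step of a 1.1-fold higher number from compound 1 to compound 4 (0.03 log units; within the scatter).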

Compound 4, half-maximal cytotoxic concentration: 302000 nM
Estimate against measurement, compound 4: 1.1-fold (0.03 log units) below; the range from low to high includes it.
By their numbers in this assay, from the lowest: compounds 1, 2, 4 and 3 (each within the scatter of the next).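

In this assay, the fourth group at this place, on an aromatic carbon ortho to a large group, again leaves the number within the scatter of all three earlier compounds: fluoro in place of methyl (a 1.1-fold higher number from compound 1 to compound 4 (0.05 log units; within the scatter)), fluoro in place of chloro (a 1.1-fold higher number from compound 2 to compound 4 (0.03 log units; within the scatter)) and fluoro in place of methoxy (a 1.0-fold lower number from compound 3 to compound 4 (0.01 log units; within the scatter)). The earlier compounds shown here showed this flat reading for methyl, chloro and methoxy only, and it now also covers fluoro, so on this read-out the four compounds cannot be told apart and none of the changes among them registers as a real step. No other kind of measurement accompanies these numbers, so why the four groups read alike remains unexplained.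

The compounds shown leave open whether this flat reading would survive a very different group at the same place, such as an amine, a carboxylic acid or a longer chain. They also leave open whether fluoro, chloro, methoxy or methyl would read alike on a different carbon of this aromatic ring, or with a change made elsewhere in the shared core.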